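Dimethylphenyl for halophenyl on the triazole nitrogen: the limit

A few compounds are considered here, and "the series" means these few. Any claim that something is new, unique, unknown or untested is made for them only; others in the source may bear on it.

Measured compounds in an ADME assay on L02 cells (Homo sapiens) for antiproliferative activity, read by MTT assay, with a stated time of 48 h; a lower number here means a stronger inhibitor, a higher number a weaker inhibitor:
compound 1 `N#CC1=C(N)Oc2c(c3nc4ccccc4nc3c3ccccc23)C12C(=O)N(Cc1cnnn1-c1cccc(Cl)c1)c1ccccc12` gives 35200 nM.
compound 2 `Cc1cc(C)cc(-n2nncc2CN2C(=O)C3(C(C#N)=C(N)Oc4c3c3nc5ccccc5nc3c3ccccc43)c3ccccc32)c1` gives only a limit of the assay, > 50000 nM.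
compound 3 `N#CC1=C(N)Oc2c(N)cc3nc4ccccc4nc3c2C12C(=O)N(Cc1cnnn1-c1cccc(Br)c1)c1ccccc12` gives only a limit of the assay, > 50000 nM.

Compound 3 thus stands at the upper edge of what this assay reports; it has no number of its own, and two of the three values shown sit at that same edge, namely (the limit of > 50000 nM in this assay, at which 2 of the 3 values shown sit). Among the compounds with values here, the one measured step that bears on the next compound is an at least 1.4-fold higher number from compound 1 to compound 2 (0.15 log units; that floor lies within the scatter), a dimethylphenyl taking the place of a halophenyl on the triazole nitrogen; the size of that step is capped because of the limit of > 50000 nM in this assay, at which 2 of the 3 values shown sit.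

Compound 4 `Cc1ccc(C)c(-n2nncc2CN2C(=O)C3(C(C#N)=C(N)Oc4c(N)cc5nc6ccccc6nc5c43)c3ccccc32)c1` carries the same kind of change against compound 3: 2,5-dimethylphenyl in place of 3-bromophenyl on an aromatic nitrogen. Given that compound 3 already sits at the limit and that the related step moved toward the limit, no movement beyond the scatter toward a lower number is expected; the estimated step is a step that the limit leaves unreadable from compound 3 to compound 4. Compound 4 is therefore expected to give about 65000 nM, with a range from 35000 nM to 120000 nM, most likely reported again only as a limit of this assay.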

Compound 4, half-maximal inhibitory concentration: > 50000 nM
Compound 4 was reported as a limit (the forecaster's own chance of this, stated with the estimate: 80%); the middle value lies beyond the limit too.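

In this assay compound 4 gives > 50000 nM, a limit of the assay and not a number. With compound 3 at the same limit, no step between the two can be read: the limit of > 50000 nM in this assay, at which 3 of the 4 values shown sit.

Left open is whether 2,5-dimethylphenyl and 3-bromophenyl on the aromatic nitrogen differ at all in this read-out, and how far beyond the limit compound 3 and compound 4 lie.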